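Carbamate terminus variation on a shared core

This account rests on a few compounds, and the source may have more. Where it says the series, first, only, none or still open, it means among the compounds named here.

Measured compounds:
compound 1 `CC(C)(C)OC(=O)N1CCC(Oc2cccc3c2CCN3c2ccc(S(C)(=O)=O)cc2)CC1` — 92%
compound 2 `CC(C)OC(=O)N1CCC(Oc2ncnc3c2CCN3c2ccc(-c3nccs3)cc2F)CC1` — 74%
compound 3 `CCCOC(=O)N1CCC(Oc2ncnc3c2CCN3c2ccc(S(C)(=O)=O)cc2F)CC1` — 111%

In a functional assay on CHO-K1 cells with Glucose-dependent insulinotropic receptor (Homo sapiens) as the target, read by a luciferase reporter, with a stated time of 5 h (on this read-out lower numbers stand for smaller maximal responses and higher numbers for larger maximal responses), compound 3 gives 111%, the highest of the three numbers; the gap to compound 1 and the wider gap to compound 2 both lie beyond the scatter. Compound 4 `CSC(=O)N1CCC(Oc2ncnc3c2CCN3c2ccc(S(C)(=O)=O)cc2F)CC1` differs from compound 3 in one place: methylsulfanyl in place of propoxy on a carbonyl carbon. Among the compounds with values here, no step between measured compounds covers this change, so its effect is not known from the series. The three measured values all sit near or above the reference while differing at this terminus. A modest step is expected in this assay, downward or none beyond the scatter. The step from compound 3 to compound 4 is estimated as a number 11 percentage points lower from compound 3 to compound 4 (beyond the scatter). Compound 4 is expected to give 100%, with a range from 75% to 120%.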

Compound 4, largest response reached (reported as percent of maximum), in percent of the reference or control that the assay uses: 135%
Compound 4: the middle estimate sits 35 percentage points below what was measured; the measured number lies above the stated range.
By their numbers in this assay, from the lowest: compound 2; then compound 1; then compound 3; then compound 4.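

In this assay, methylsulfanyl in place of propoxy on a carbonyl carbon gives a number 24 percentage points higher from compound 3 to compound 4 (beyond the scatter). Within the data shown here, this is the first single-place step at this terminus, and it shows that the propoxy group can be replaced here without loss of maximal response. No available measurement accounts for the rise.

The two compounds change the chain and the linking atom together, so the contribution of each remains unresolved. A methoxy or propylsulfanyl group on the same carbonyl carbon would separate the two changes.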